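Swapping the Aromatic Group on the Shared Core's Amine

The source may report more compounds than this note shows. Statements on the series, on what has been measured and on what is new or still open speak of the compounds shown alone.

Among the measured compounds shown here, the two compounds measured so far share one core and differ only in the aromatic group carried on a nitrogen on an aromatic ring. Compound 1 `COc1cc(NC(=O)Nc2cc(Nc3cccc(C(C)(C)C)c3)ncn2)cc(OC)c1` carries a 3-(tert-butyl)phenyl there, and compound 2 `COc1cc(NC(=O)Nc2cc(Nc3ccc(C)c(F)c3)ncn2)cc(OC)c1` a 3-fluoro-4-methylphenyl. For the measured compounds named here, in a functional assay on HCC827 cells (Homo sapiens) for inhibition, read by MTT assay, with a stated time of 48 h, tested at 10 uM (a lower number here means less inhibition, a higher number more inhibition at the concentration tested (going by the name of the read-out)), compound 1 gives 48.7%, while compound 2 gives 72%, the higher of the two numbers; the single step between them, a number 23.3 percentage points higher from compound 1 to compound 2 (beyond the scatter), lies beyond the scatter.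

Compound 3 `CCc1cccc(Nc2cc(NC(=O)Nc3cc(OC)cc(OC)c3)ncn2)c1` has not yet been measured. It differs from compound 2 at the same place: 3-ethylphenyl in place of 3-fluoro-4-methylphenyl on a nitrogen on an aromatic ring.

Going by the values given here, the only measured step that bears on this change is a number 23.3 percentage points higher from compound 1 to compound 2 (beyond the scatter), which shows that exchanging the aromatic group on this nitrogen can shift the read-out by a modest amount. Among the compounds with values here, no measured pair involves a 3-ethylphenyl, so the direction remains uncertain, and a small drop is expected as the likeliest outcome, the expected step being a number 12 percentage points lower from compound 2 to compound 3 (beyond the scatter). In this assay compound 3 is estimated at 60%, within a range from 40% to 78%.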

Compound 3, a percentage reported as inhibition, at one concentration (the size of the read-out at that concentration, not a potency): 52.6%
Compound 3: middle estimate off by 7.4 percentage points, on the high side; the range from low to high includes it.
By their numbers in this assay, from the lowest: compounds 1 and 3 (each within the scatter of the next); then compound 2.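

This second change at the nitrogen shows that the higher number of compound 2 does not carry over to every substituted phenyl group: in this assay, 3-ethylphenyl in place of 3-fluoro-4-methylphenyl gives a number 19.4 percentage points lower from compound 2 to compound 3 (beyond the scatter). The new compound also allows a comparison that the first pair could not: ethyl in place of tert-butyl on an aromatic carbon gives a number 3.9 percentage points higher from compound 1 to compound 3 (within the scatter), so this assay does not separate those two groups. Among these three compounds, the 3-fluoro-4-methylphenyl group of compound 2 therefore stands apart, while the groups of compound 1 and compound 3 give numbers that cannot be told apart. Nothing available here explains why the read-out moves with these changes.

The compounds shown leave open whether the fluorine, the methyl or the two together in compound 2 account for its higher number, as both differ from the groups in compound 1 and compound 3. They also leave open how this read-out would respond to a more different group on the same aromatic ring, such as an amine or a carboxylic acid.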